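Swapping thiophen-3-yl for 1-benzofuran-2-yl

The compounds below may be only part of what the source reports. "The series", "measured", "known", "first", "only" and "open" are said of these compounds alone.

Compound 1 `Cc1ncnc2c1c(-c1ccoc1)cn2[C@@H]1O[C@H](CO)[C@@H](O)[C@H]1O`: > 20000 nM
Compound 2 `Cc1ncnc2c1c(-c1ccsc1)cn2[C@@H]1O[C@H](CO)[C@@H](O)[C@H]1O`: 11200 nM

Within the data shown here, in a functional assay on CCRF-CEM cells (Homo sapiens), read by MTT assay, with a stated time of 72 h (a higher number here means a weaker inhibitor, a lower number a stronger inhibitor), compound 2 gives 11200 nM, the only exact number so far. For compound 1, the reading > 20000 nM is a limit, not a number. Among the measured compounds shown here, the one measured step is an at least 1.7-fold lower number from compound 1 to compound 2 (0.25 log units; that floor lies within the scatter). Compound 3 `Cc1ncnc2c1c(-c1cc3ccccc3o1)cn2[C@@H]1O[C@H](CO)[C@@H](O)[C@H]1O` has 1-benzofuran-2-yl in place of thiophen-3-yl on an aromatic carbon. With only an at least 1.7-fold lower number from compound 1 to compound 2 (0.25 log units; that floor lies within the scatter) to go on, no step beyond the scatter is expected in this assay. The expected step is a 1.1-fold lower number from compound 2 to compound 3 (0.05 log units; within the scatter). Compound 3 is estimated at 10000 nM, within an expected range of 3000 nM to 20000 nM.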

Compound 3, half-maximal inhibitory concentration: 17300 nM
Compound 3: middle estimate off by 1.7-fold (0.24 log units), on the low side, within the range that was stated.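

In this assay, 1-benzofuran-2-yl brings a second aromatic ring to this carbon, yet the result is a 1.5-fold higher number from compound 2 to compound 3 (0.19 log units; within the scatter), so the larger group does not shift the reading beyond the scatter. The change from furan-3-yl gives an at least 1.1-fold lower number from compound 1 to compound 3 (0.06 log units; that floor lies within the scatter); this is only a floor, because one of the two readings is a limit: the limit of > 20000 nM in this assay, at which 1 of the 3 values shown sits. Still open, going by these compounds, is whether a non-aromatic group on this carbon, such as an amine, a carboxylic acid or a longer chain, would move the reading beyond the scatter.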